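An Aromatic Nitrogen Loses Its Methyl

The source may hold more compounds than are shown below. What is called first, only, known or untested is meant among the compounds shown, and "the series" means these compounds.

Of the compounds shown here, three have been tested in a functional assay on MV4-11 cells (Homo sapiens) for antiproliferative activity, with a stated time of 6 days, tested at 1.56 uM; on this read-out lower numbers stand for a weaker effect and higher numbers for a stronger effect at the one concentration tested. Compound 1, `CNC(=O)N1CCCc2ccc(NC(=O)c3ccc(-c4cc[nH]n4)cc3)cc21`, gives 92.5% in this assay. Compound 2, `CNC(=O)N1CCCc2ccc(NC(=O)c3ccc(-c4ccn(C)n4)cc3)cc21`, gives 72.2%. Compound 3, `CNC(=O)N1CCCc2ccc(NC(=O)c3cccc(-c4cnn(C)c4)c3)cc21`, gives 71.2%, the lowest of the three numbers, though its gap to compound 2 lies within the usual scatter and only its gap to compound 1 lies beyond it.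

Compounds 2 and 1 differ in one place: hydrogen in place of methyl on an aromatic nitrogen. That single change made a number 20.3 percentage points higher from compound 2 to compound 1 (beyond the scatter), a modest gain. Compounds 2 and 3 are built from the same atoms joined differently; the difference between the two cores is not broken down here.

Compound 4, `CNC(=O)N1CCCc2ccc(NC(=O)c3cccc(-c4cn[nH]c4)c3)cc21`, is still unmeasured. It stands to compound 3 as compound 1 stands to compound 2: hydrogen in place of methyl on an aromatic nitrogen. The description of the place reads the same word for word in both cases, so this is the same change, made on a different core. Within the data shown here, one measured example is a thin basis, and the cores are not the same, yet the only example available points upward. Resting on a number 20.3 percentage points higher from compound 2 to compound 1 (beyond the scatter), the step to compound 4 is expected to be a number 14.8 percentage points higher from compound 3 to compound 4 (beyond the scatter). In this assay compound 4 is therefore expected to give about 86%, within a range from 70% to 97%.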

Compound 4, a percentage reported as inhibition, at one concentration (the size of the read-out at that concentration, not a potency): 27.9%
Estimate against measurement, compound 4: 58.1 percentage points above; measured number below the stated range.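

In this assay, putting hydrogen in place of methyl on the aromatic nitrogen, which turns 1-methyl-1H-pyrazol-4-yl into 1H-pyrazol-4-yl, gave a number 43.3 percentage points lower from compound 3 to compound 4 (beyond the scatter), a large loss rather than a gain. The result of this change therefore depends on the core that carries it, and a step seen on one core in this series cannot simply be carried over to the other, since the two steps point in opposite directions: the same change on two cores in this assay, a number 20.3 percentage points higher (beyond the scatter) from compound 2 to compound 1 and a number 43.3 percentage points lower (beyond the scatter) from compound 3 to compound 4, 63.6 percentage points apart, beyond the scatter of two such steps

Among these compounds, this does not show which feature of the cores reverses the step, as the two cores differ in how their atoms are joined and only one pair has been measured on each, with every number read at a single concentration and so not a potency. The compounds shown leave open what an ethyl group or a longer chain on that aromatic nitrogen would do on either core. They also leave open whether the opposite steps would persist at other concentrations.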